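From Methyl to Hydroxy: Estimating Compound 3

The source may report more compounds than this note shows. Statements on the series, on what has been measured and on what is new or still open speak of the compounds shown alone.

Measured so far:
Compound 1 `Cc1ccc(/C=N/NC(=S)N2CCNCC2)cc1` gives 800 nM
Compound 2 `S=C(NN=C(c1ccccc1)c1ccccc1)N1CCNCC1` gives 340 nM

For the measured compounds named here, in a functional assay on HBL-100 cells (Homo sapiens) for antiproliferative activity, read by MTT assay, with a stated time of 72 h (on this read-out lower numbers stand for stronger inhibition and higher numbers for weaker inhibition), compound 1 stands at 800 nM, the higher of the two numbers measured so far, while compound 2 gives 340 nM, a lower number that lies beyond the usual scatter. Compound 3 `Oc1ccc(/C=N/NC(=S)N2CCNCC2)cc1` differs from compound 1 by hydroxy in place of methyl on an aromatic carbon. Going by the values given here, no measured pair shows this particular change, so its effect is unknown. The step of a 1.1-fold higher number from compound 1 to compound 3 (0.05 log units; within the scatter) is expected to be none beyond the scatter. Compound 3 is therefore estimated at 900 nM, with a plausible range from 300 nM to 2700 nM.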

Compound 3, half-maximal inhibitory concentration: 180 nM
For compound 3 the middle estimate is 5.0-fold (0.70 log units) above the measured one; the whole stated range lies above it.
By their numbers in this assay, from the lowest: compounds 3 and 2 (each within the scatter of the next); then compound 1.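

In this assay, for the compounds shown here, hydroxy in place of methyl on an aromatic carbon gives a 4.4-fold lower number from compound 1 to compound 3 (0.65 log units; beyond the scatter), so what sits at this position matters, even though only one heavy atom changes. Compounds 1 and 2 differ in more than one place and could not show this. No measurement here explains the shift. From the compounds shown here alone, only methyl and hydroxy appear at this position, so it remains open how an amine, a methoxy group or a carboxylic acid would behave there. Going by these compounds, whether the same change has a similar effect on another core also remains open.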